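This account rests on a few compounds, and the source may have more. Where it says the series, first, only, none or still open, it means among the compounds named here.

Series notes, binding at an in vitro assay on SH-EP1 cells for displacement of a labelled ligand from Neuronal acetylcholine receptor; alpha4/beta2 (Homo sapiens); on this read-out lower numbers stand for stronger inhibition and higher numbers for weaker inhibition:

- compound 1, `COc1cc(C2=CC3CC(C2)CN(C)C3)cnc1Cl`: 4.4 nM
- compound 2, `CN1CC2C=C(c3cnccc3Cl)CC(C2)C1`: 1160 nM
- compound 3, `Clc1ccc(Oc2cncc(C3=CC4CNCC(C3)C4)c2)cc1`: 1.9 nM

Compound 3 gives the lowest number of the three in this assay. The gap to compound 1 is beyond the scatter, and the gap to compound 2 is far beyond it, so compound 3 stands as the strongest binder of the measured set.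

The next compound, compound 4 `CC(C)Oc1cncc(C2=CC3CNCC(C2)C3)c1`, keeps the shared core of compound 3 and changes only the group on the ether oxygen: isopropyl in place of 4-chlorophenyl on an oxygen on an aromatic ring. Going by the values given here, no pair of measured compounds differs in exactly this way, so the size of the step has to be guessed from what the set shows. Compound 1 carries a small alkoxy group on its aromatic ring and still gives 4.4 nM, which argues that a large aryl on the oxygen is not required for a low number, while compound 2, with no oxygen substituent at all, gives 1160 nM.

The expectation for compound 4 is a small loss relative to compound 3, of about a 4.2-fold higher number from compound 3 to compound 4 (0.62 log units; beyond the scatter), possibly within the scatter. Compound 4 is therefore estimated at 8 nM, with a range from 2.5 nM to 25 nM.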

Compound 4, inhibition constant: 0.26 nM
Beside the measured number, compound 4's estimate is 31-fold (1.49 log units) above it, outside the stated range (below it).
By their numbers in this assay, from the lowest: compound 4; then compound 3; then compound 1; then compound 2.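

In this assay, the oxygen on the aromatic ring accepts a large change in its substituent: isopropyl in place of 4-chlorophenyl gives a 7.3-fold lower number from compound 3 to compound 4 (0.86 log units; beyond the scatter). At this position, therefore, neither an aromatic ring on the oxygen nor the chlorine it carries is needed for a low number, and the small branched group without a ring is the better of the two substituents shown. The data offer no measurement that accounts for this step, so it stands as an observation only.

This single step changes the ring, the chlorine and the size of the group together, so the contribution of each stays unresolved; methyl, ethyl, cyclopentyl or an unsubstituted phenyl on the same oxygen would help to separate them. Also open, on these data alone, is how far the oxygen substituent can be changed in other directions, for instance to a longer alkyl chain or to a chain ending in an amine or a carboxylic acid, and whether the low number of compound 4 would hold there.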